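A few compounds are considered here, and "the series" means these few. Any claim that something is new, unique, unknown or untested is made for them only; others in the source may bear on it.

Measured so far:
compound 1 `O=C1N=C(C2C(=O)c3ccccc3C2=O)CC(c2ccccc2[N+](=O)[O-])N1`: 30%
compound 2 `O=C1N=C(C2C(=O)c3ccccc3C2=O)CC(c2cccc([N+](=O)[O-])c2)N1`: 36%
compound 3 `O=C1N=C(C2C(=O)c3ccccc3C2=O)CC(c2ccc(Cl)cc2)N1`: 19%

In a functional assay on the whole organism for inhibition, with Rattus norvegicus as the target, read by paw edema, with stated times of 30 min and 2 h, at a dose of 10 mg/kg by the oral route (on this read-out higher numbers stand for more inhibition at the one dose given (going by the name of the read-out) and lower numbers for less inhibition), compound 2 and compound 1 stand within the scatter of each other (a number 6 percentage points higher from compound 1 to compound 2 (within the scatter)), while compound 3 lies beyond it (a number 17 percentage points lower from compound 2 to compound 3 (beyond the scatter); also a number 11 percentage points lower from compound 1 to compound 3 (beyond the scatter)). Compound 4 `O=C1N=C(C2C(=O)c3ccccc3C2=O)CC(c2ccccc2O)N1` is not yet measured. The change is 2-hydroxyphenyl in place of 3-nitrophenyl on a saturated ring carbon. Every measured step swaps the aryl group on the same saturated ring carbon, and the two steps beyond the scatter both end at the chlorophenyl of compound 3 and are modest. Among the compounds with values here, no step tests a hydroxyl entering or a nitro group leaving, so the direction rests on analogy alone; a modest downward step or none beyond the scatter seems most likely. For compound 4 an inhibition of 27% is expected, within 14% to 40%. This estimate means an expected step of a number 9 percentage points lower from compound 2 to compound 4 (within the scatter).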

Compound 4, a percentage reported as inhibition, in the whole organism at one dose (the size of the read-out at that dose, not a potency): 22%
Compound 4: middle estimate off by 5 percentage points, on the high side, within the range that was stated.
By their numbers in this assay, from the lowest: compounds 3, 4, 1 and 2 (each within the scatter of the next, the first and the last beyond it).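

Hydroxy-bearing aryl on this saturated ring carbon now has a reading in this assay: 2-hydroxyphenyl in place of 3-nitrophenyl gives a number 14 percentage points lower from compound 2 to compound 4 (beyond the scatter). The direct swap of hydroxy for nitro on the same aromatic carbon stays small, with a number 8 percentage points lower from compound 1 to compound 4 (within the scatter), and 2-hydroxyphenyl against 4-chlorophenyl gives a number 3 percentage points higher from compound 3 to compound 4 (within the scatter), so this aryl change separates compound 4 only from compound 2. Nothing available explains these steps.

On these data alone, whether an amine or a carboxylic acid on this aryl ring would read with compound 2 or with compound 4 remains open. A single dose also leaves potency unresolved.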